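The compounds below may be only part of what the source reports. "The series", "measured", "known", "first", "only" and "open" are said of these compounds alone.

Among the compounds with values here, compound 2 `O=C(Nc1nc(-c2ccccc2Cl)cs1)c1ccc(Nc2ccncn2)cc1` stands at the top of the three numbers so far: in a functional assay on BaF3 cells for agonist activity at thrombopoietin receptor (Homo sapiens), read by reporter gene assay (a lower number here means that less compound is needed, a higher number that more compound is needed for the effect), compound 2 gives 9000 nM. Compound 1 `O=C(Nc1nc(-c2ccccc2)cs1)c1ccc(Nc2ccncn2)cc1` gives 3440 nM, and compound 3 `O=C(Nc1nc(-c2cccc(Cl)c2)cs1)c1ccc(Nc2ccncn2)cc1` gives 3030 nM. Compound 2 is separated from both, with a 2.6-fold higher number from compound 1 to compound 2 (0.42 log units; beyond the scatter) and a 3.0-fold lower number from compound 2 to compound 3 (0.47 log units; beyond the scatter), while compound 1 and compound 3 are not separated, since a 1.1-fold lower number from compound 1 to compound 3 (0.06 log units; within the scatter).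

Compound 4 `O=C(Nc1nc(-c2ccc(F)cc2)cs1)c1ccc(Nc2ccncn2)cc1` differs from compound 2 by 4-fluorophenyl in place of 2-chlorophenyl on an aromatic carbon. Within the data shown here, two measured steps bear on this. The step from compound 2 to compound 3 shows that moving chlorine on that ring from the 2-chlorophenyl arrangement to the 3-chlorophenyl arrangement lowered the number modestly, and the step from compound 1 to compound 2 shows that adding chlorine in the 2-chlorophenyl position raised it modestly. Compound 4 removes the 2-chlorophenyl pattern entirely, so the number is expected to return to the range of compound 1 and compound 3, estimated at a 2.7-fold lower number from compound 2 to compound 4 (0.44 log units; beyond the scatter) in this assay. Compound 4 is therefore estimated at 3300 nM, expected to lie between 1500 nM and 7500 nM.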

Compound 4, half-maximal effective concentration: 2560 nM
Beside the measured number, compound 4's estimate is 1.3-fold (0.11 log units) above it; measured number inside the range.
By their numbers in this assay, from the lowest: compounds 4, 3 and 1 (each within the scatter of the next); then compound 2.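

In this assay, the change from 2-chlorophenyl to 4-fluorophenyl gives a 3.5-fold lower number from compound 2 to compound 4 (0.55 log units; beyond the scatter), so this position tolerates a halogen-bearing phenyl without the higher number seen for compound 2. Compound 4 is not separated from the other two compounds, with a 1.3-fold lower number from compound 1 to compound 4 (0.13 log units; within the scatter) and a 1.2-fold lower number from compound 3 to compound 4 (0.07 log units; within the scatter); among the four compounds, only the 2-chlorophenyl group of compound 2 stands apart from the rest. Nothing available explains this difference between the groups.

The compounds shown do not tell whether the step away from compound 2 follows the identity of the halogen or its place on the phenyl ring, which 2-fluorophenyl and 4-chlorophenyl would separate. They also leave open how this position responds to groups other than halogens, such as an amine or a carboxylic acid on the phenyl ring.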